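The compounds below may be only part of what the source reports. "The series", "measured", "known", "first", "only" and "open" are said of these compounds alone.

Compound 1 `COc1ccc(Nc2cc(C)nc(SCc3nc4ccccc4[nH]3)n2)cc1`: 67400 nM
Compound 2 `Cc1cc(Nc2ccc(F)cc2)nc(SCc2nc3ccccc3[nH]2)n1`: 56200 nM

In a functional assay on PC-3 cells (Homo sapiens) for cytotoxicity, read by MTT assay, with a stated time of 72 h (a lower number here means a stronger inhibitor, a higher number a weaker inhibitor), compound 2 gives the lowest of the two numbers, but its neighbour compound 1 sits within the scatter of it, so the two cannot be ordered. Compound 3 `Cc1cc(NC(C)C)nc(SCc2nc3ccccc3[nH]2)n1` differs from compound 2 by isopropyl in place of 4-fluorophenyl on a nitrogen on an aromatic ring. Among the measured compounds shown here, the one measured step, a 1.2-fold lower number from compound 1 to compound 2 (0.08 log units; within the scatter), swaps one group for another on the 4-fluorophenyl ring and says nothing about removing that ring altogether, so no step bears directly on this change. Compound 3 is therefore expected to remain a weak inhibitor, with a step of a 1.6-fold higher number from compound 2 to compound 3 (0.20 log units; within the scatter), giving an estimate of 90000 nM with a range from 30000 nM to 300000 nM.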

Compound 3, half-maximal inhibitory concentration: > 100000 nM
Compound 3 ended at the assay's limit (the forecaster's own chance of this, stated with the estimate: 25%); middle value at least 1.1-fold (0.04 log units) away from the limit.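

In this assay compound 3 stands at a limit, not at a number: the limit of > 100000 nM in this assay, at which 1 of the 3 values shown sits. The earlier compounds shown here changed only a group on the ring, whereas here the ring on the nitrogen gives way to isopropyl, with an at least 1.7-fold higher number from compound 2 to compound 3 (0.25 log units; that floor lies within the scatter) and an at least 1.4-fold higher number from compound 1 to compound 3 (0.17 log units; that floor lies within the scatter). Both floors lie within the scatter, so this change cannot be ordered against the ring-bearing compounds, and its true size remains unread.

On these data alone, how far compound 3 lies beyond its limit remains open. So does whether a cyclohexyl group or a longer chain ending in an amine on that nitrogen would give a readable number.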